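Hydroxy for methyl on the sulfonamide chain

The source may report more compounds than this note shows. Statements on the series, on what has been measured and on what is new or still open speak of the compounds shown alone.

Among the compounds with values here, compound 1 `CCCNS(=O)(=O)c1ccc(Nc2ncc3c(n2)N(C2CCCC2)[C@H](CC)C(=O)N3C)cc1` is the only member with a single number: in a functional assay on MCF7 cells (Homo sapiens) for antiproliferative activity, read by CCK-8 assay, with a stated time of 72 h (on this read-out higher numbers stand for weaker inhibition of growth and lower numbers for stronger inhibition of growth), compound 1 gives 344 nM. Within the data shown here, compound 2 `CC[C@@H]1C(=O)N(C)c2cnc(-n3ccc4cc(F)ccc43)nc2N1C1CCCC1` is reported in this assay as "not active" (no number reported), without a number, so no step can be drawn from it. Compound 3 `CC[C@@H]1C(=O)N(C)c2cnc(Nc3ccc(S(=O)(=O)NCCO)cc3)nc2N1C1CCCC1` differs from compound 1 by hydroxy in place of methyl on a saturated chain carbon, two bonds along the chain from a sulfonamide nitrogen. Among the measured compounds shown here, no step between measured compounds anchors this change, so the step in this assay is expected to stay within the usual scatter, with no direction favoured. In this assay compound 3 is estimated at 400 nM, with a range from 150 nM to 1100 nM. The expected step of a 1.2-fold higher number from compound 1 to compound 3 (0.07 log units; within the scatter) is taken as within the scatter.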

Compound 3, concentration for 50% growth inhibition: 344 nM
Beside the measured number, compound 3's estimate is 1.2-fold (0.07 log units) above it, within the range that was stated.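

In this assay, hydroxy in place of methyl on a saturated chain carbon, two bonds along the chain from a sulfonamide nitrogen, gives no change at the digits printed from compound 1 to compound 3 (within the scatter). Within the data shown here, this is the first step readable, and it shows that this change at this position leaves the number in place. No available evidence bears on what lies behind this result.

Going by these compounds, whether an amine or a carboxylic acid in place of the hydroxy would also leave the number in place remains open. So does the outcome for a longer chain carrying the hydroxy.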